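A few compounds are considered here, and "the series" means these few. Any claim that something is new, unique, unknown or untested is made for them only; others in the source may bear on it.

Measured compounds:
compound 1, `CC(C)c1c(C(=O)N(C)Cc2ccccc2)nn(-c2ccc(F)cc2)c1CC[C@@H](O)C[C@@H](O)CC(=O)O`, gives 6.2 nM in an assay on microsomes from liver for inhibition of 3-hydroxy-3-methylglutaryl-coenzyme A reductase (Rattus norvegicus); on this read-out lower numbers stand for stronger inhibition and higher numbers for weaker inhibition
compound 2, `CC(C)c1c(C(=O)NCc2ccccc2)nn(-c2ccc(F)cc2)c1OC[C@@H](O)C[C@@H](O)CC(=O)O`, gives 3.8 nM in this assay
compound 3, `CC(C)c1c(C(=O)N(C)Cc2ccccc2)nn(-c2ccc(F)cc2)c1OC[C@@H](O)C[C@@H](O)CC(=O)O`, gives 5.2 nM in this assay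

Compound 3 stands at the second highest of the three numbers in this assay. Its nearest neighbour is compound 1, with a 1.2-fold lower number from compound 1 to compound 3 (0.08 log units; within the scatter); the furthest is compound 2, with a 1.4-fold higher number from compound 2 to compound 3 (0.14 log units; within the scatter). Neither separation leaves the scatter, so the three compounds cannot be ordered on these numbers.

Compound 4, `CC(C)c1c(C(=O)NCc2cccc(F)c2F)nn(-c2ccc(F)cc2)c1OC[C@@H](O)C[C@@H](O)CC(=O)O`, has not yet been measured in this assay. It differs from compound 3 in one place: (2,3-difluorobenzyl)amino in place of benzyl(methyl)amino on a carbonyl carbon. Of the measured steps, a 1.4-fold higher number from compound 2 to compound 3 (0.14 log units; within the scatter) bears on it, since it exchanges hydrogen and methyl on the same amide-type nitrogen and stays within the scatter. Going by the values given here, no measured compound carries the two fluorines on the benzyl ring, so that part of the change is uncovered by the data. Compound 4 is therefore expected to give 4 nM, with a range from 1.5 nM to 12 nM. The expected step is a 1.3-fold lower number from compound 3 to compound 4 (0.11 log units; within the scatter), in no direction beyond the scatter.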

Compound 4, half-maximal inhibitory concentration: 2 nM
For compound 4 the middle estimate is 2.0-fold (0.30 log units) above the measured one, within the range that was stated.
By their numbers in this assay, from the lowest: compounds 4, 2, 3 and 1 (each within the scatter of the next, the first and the last beyond it).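

In this assay, going by these compounds alone, the exchange of benzyl(methyl)amino for (2,3-difluorobenzyl)amino on the carbonyl carbon is the first change to leave the scatter, with a 2.6-fold lower number from compound 3 to compound 4 (0.41 log units; beyond the scatter), though the step is only modest. Neither part of the exchange does this on its own: the methyl-for-hydrogen step between compound 2 and compound 3 stays within the scatter, and so does the addition of the two fluorines, with a 1.9-fold lower number from compound 2 to compound 4 (0.28 log units; within the scatter), so only the two changes taken together separate compound 4 from compound 3. Nothing measured here gives a reason for this step.

The compounds shown leave open whether the two fluorines would have the same effect with the methyl kept on the amide nitrogen. They also leave open how a cyclohexylmethyl or pyridylmethyl group on that nitrogen would compare.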